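Para substituent swap on the hydrazone series

The source may hold more compounds than are shown below. What is called first, only, known or untested is meant among the compounds shown, and "the series" means these compounds.

Compound 2 `COc1ccc(/C=N/N(Cc2ccccc2)Cc2ccccc2)cc1` gives 220 nM in an assay on liver (Sus scrofa) for inhibition of glucose-6-phosphatase catalytic subunit 1 (Homo sapiens), using microsomes (a lower number here means a stronger inhibitor, a higher number a weaker inhibitor), and stands lowest of the two numbers shown. Compound 1 `c1ccc(CN(Cc2ccccc2)/N=C2\CCCc3ccccc32)cc1` gives 25000 nM in this assay. Compound 3 `COc1ccccc1/C=N/N(Cc1ccccc1)Cc1ccccc1` reaches only the assay limit > 100000 nM in this assay (the limit of > 100000 nM in this assay, at which 1 of the 3 values shown sits). Within the data shown here, the one measured step, an at least 450-fold higher number from compound 2 to compound 3 (2.65 log units; beyond the scatter), relocates the methoxy rather than exchanging it. Compound 4 `CN(C)c1ccc(/C=N/N(Cc2ccccc2)Cc2ccccc2)cc1` differs from compound 2 by dimethylamino in place of methoxy on an aromatic carbon. Among the measured compounds shown here, no measured step exchanges the group at that ring carbon, so the measured step bears on it only by showing that this position is sensitive. A step within or just beyond the scatter in this assay, in either direction, is expected for compound 4, as a 1.5-fold lower number from compound 2 to compound 4 (0.17 log units; within the scatter). Compound 4 is estimated at 150 nM, between 40 nM and 800 nM.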

Compound 4, half-maximal inhibitory concentration: 100000 nM
Compound 4: the middle estimate sits 670-fold (2.82 log units) below what was measured; the whole stated range lies below it.
By their numbers in this assay, from the lowest: compound 2; then compound 1; then compound 4.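

With dimethylamino in place of methoxy on an aromatic carbon, para to a large group, the series shows a 450-fold higher number from compound 2 to compound 4 (2.66 log units; beyond the scatter), so this ring carbon responds to which group it carries, not only to where the methoxy sits. The counts of donors and acceptors and the net charge do not separate the two groups. The higher number of this step stands at the figure of the assay limit: the limit of > 100000 nM in this assay, at which 1 of the 4 values shown sits.

From the compounds shown here alone, whether a hydroxyl, an ethoxy or a primary amine at this ring carbon keeps a number near that of compound 2 remains open.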